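Bromo to formyl: estimating the maximal response of compound 4

A few compounds are considered here, and "the series" means these few. Any claim that something is new, unique, unknown or untested is made for them only; others in the source may bear on it.

Measured compounds:
- compound 1, `CCOc1ccccc1OC(C)C1=NCCN1`: in an assay on CHO cells with Alpha-2C adrenergic receptor (Homo sapiens) as the target (on this read-out lower numbers stand for smaller maximal responses and higher numbers for larger maximal responses), compound 1 gives 0.45
- compound 2, `C=CCc1cccc(CC=C)c1OC(C)C1=NCCN1`: in this assay compound 2 gives 0.9
- compound 3, `CC(Oc1ccccc1Br)C1=NCCN1`: in this assay compound 3 gives 0.87

Compound 3 stands second highest of the three numbers. Its value and that of compound 2 lie within the usual scatter of each other, so nothing separates them. Compound 1 lies well below: the step a number 0.42 higher from compound 1 to compound 3 (beyond the scatter) is large and clearly beyond the scatter.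

Compound 4, `CC(Oc1ccccc1C=O)C1=NCCN1`, has not yet been measured in this assay. It differs from compound 3 in one place: formyl in place of bromo on an aromatic carbon.

For the measured compounds named here, only one measured step bears on this change, the replacement of ethoxy by bromo, a number 0.42 higher from compound 1 to compound 3 (beyond the scatter), which moved the number up by a large amount. Going by the values given here, no measured step involves a formyl group, so its effect is unknown. Taking bromo away again removes the group that accompanied the large rise, but the group that replaces it is not the ethoxy of compound 1, so the full fall back to compound 1's level need not follow. The step a number 0.22 lower from compound 3 to compound 4 (beyond the scatter) is therefore expected to be downward and beyond the scatter, yet smaller than the step from compound 1 to compound 3. Compound 4 is estimated at 0.65, with a range from 0.4 to 0.9.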

Compound 4, intrinsic activity: the largest response reached, as a fraction of the reference agonist's: 0.6
For compound 4 the middle estimate is 0.050 above the measured one; low and high end bracket the measured number.
By their numbers in this assay, from the lowest: compound 1; then compound 4; then compounds 3 and 2 (each within the scatter of the next).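

In this assay, putting formyl in place of bromo on this aromatic carbon, ortho to a group of 8 heavy atoms, gives a number 0.27 lower from compound 3 to compound 4 (beyond the scatter) and shows that the high maximal response of compound 3 does not survive this change intact. Formyl also differs from ethoxy, with a number 0.15 higher from compound 1 to compound 4 (beyond the scatter) on the same core, so this one place now carries three groups that give three separate levels of response rather than a simple high and low. The earlier compounds showed only that ethoxy and bromo differ, whereas compound 4 adds a level between them and shows that the response at this place is not limited to those two outcomes, although nothing measured here explains the order of the three groups.

As far as these compounds go, how an amine, a carboxylic acid or a longer chain on the same aromatic carbon would compare with these three groups remains open. For the compounds shown here, it is also open whether formyl in place of bromo would give a similar step on a differently substituted core, since only one such pair is available.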